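A few compounds are considered here, and "the series" means these few. Any claim that something is new, unique, unknown or untested is made for them only; others in the source may bear on it.

Compound 1 `Cc1cn([C@H]2C=C[C@@H](CO)O2)c(=O)[nH]c1=S` in an assay on isolated protein (Oryctolagus cuniculus) for inhibition of thymidine kinase, cytosolic (Homo sapiens); a lower number here means a stronger inhibitor, a higher number a weaker inhibitor: 1690000 nM
Compound 2 `Cc1cn([C@H]2C[C@H](N=[N+]=[N-])[C@@H](CO)O2)c(=O)[nH]c1=S` in this assay: 54000 nM

Compound 2 stands lowest of the two numbers; compound 1 gives a number higher by a margin beyond the usual scatter. Compound 3 `Cc1cn([C@H]2CC[C@@H](CO)O2)c(=O)[nH]c1=S` has not yet been measured in this assay. It differs from compound 2 by hydrogen in place of azido on a saturated ring carbon. Among the compounds with values here, no measured pair shows this exact step, so its size is uncertain. Within the data shown here, the only guide is that azido-bearing compound 2 gives 54000 nM while compound 1, lacking azido, gives 1690000 nM. The expected step is a 3.7-fold higher number from compound 2 to compound 3 (0.57 log units; beyond the scatter), toward a weaker inhibitor, beyond the scatter. Compound 3 is estimated at 200000 nM, within 40000 nM to 1000000 nM.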

Compound 3, inhibition constant: 1600000 nM
Estimate against measurement, compound 3: 8.0-fold (0.90 log units) below; measured number outside the range, above it.
By their numbers in this assay, from the lowest: compound 2; then compounds 3 and 1 (each within the scatter of the next).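

In this assay, within the data shown here, hydrogen in place of azido on this saturated ring carbon gives a 30-fold higher number from compound 2 to compound 3 (1.47 log units; beyond the scatter), the first direct reading of this change. Without azido, compound 3 stands within the scatter of compound 1, so among these compounds only azido-bearing compound 2 gives the lower number. No measurement shown gives a reason for the size of this step.

Only hydrogen and azido are compared at this position. As far as these compounds go, whether an amine, a hydroxyl or a fluorine atom there would give a number nearer compound 2 or compound 3 stays open.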